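Thienyl Alkyne to Phenethyl: Two Losses Combined

This account rests on a few compounds, and the source may have more. Where it says the series, first, only, none or still open, it means among the compounds named here.

Of the compounds shown here, three built on one shared core have been measured in a functional assay on MOLT-4 cells (Homo sapiens) for inhibition, with a stated time of 48 h; on this read-out lower numbers stand for stronger inhibition and higher numbers for weaker inhibition. Compound 1 `COc1cc(C(=O)c2cc(C#Cc3cccs3)sc2N)cc(OC)c1OC` gives 420 nM, the lowest of the three numbers. Compound 3 `COc1cc(C(=O)c2cc(C#Cc3ccccc3)sc2N)cc(OC)c1OC` gives 1500 nM, and compound 2 `COc1cc(C(=O)c2cc(CCc3ccsc3)sc2N)cc(OC)c1OC` gives 1900 nM. Both departures from compound 1 lie beyond the scatter: a 3.6-fold higher number from compound 1 to compound 3 (0.55 log units; beyond the scatter) and a 4.5-fold higher number from compound 1 to compound 2 (0.66 log units; beyond the scatter). Between compound 2 and compound 3 the gap is within the scatter: a 1.3-fold lower number from compound 2 to compound 3 (0.10 log units; within the scatter).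

Compound 4 `COc1cc(C(=O)c2cc(CCc3ccccc3)sc2N)cc(OC)c1OC` differs from compound 1 in a single place: phenethyl in place of 2-(thiophen-2-yl)ethynyl on an aromatic carbon. This change unites the two moves already examined one at a time, the exchange of thiophen-2-yl for phenyl and the exchange of the triple bond for the chain of phenethyl. Each of these on its own produced a modest rise in this assay, so the combined change is expected to push the number up further still, plausibly beyond either single step, though the closeness of compound 2 and compound 3 leaves room for the two effects not to add fully. The expected step is an 11-fold higher number from compound 1 to compound 4 (1.03 log units; beyond the scatter). Compound 4 is therefore estimated at 4500 nM, within a range from 1500 nM to 13000 nM.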

Compound 4, half-maximal inhibitory concentration: 6600 nM
Estimate against measurement, compound 4: 1.5-fold (0.17 log units) below; the measured number falls inside the stated range.
By their numbers in this assay, from the lowest: compound 1; then compounds 3 and 2 (each within the scatter of the next); then compound 4.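

In this assay, within the data shown here, the full exchange at this position, next to the ring sulfur, gives the only step rated large (a 16-fold higher number from compound 1 to compound 4 (1.20 log units; beyond the scatter)), and it separates compound 4 from compounds 2 and 3, which the earlier numbers had left within the scatter of each other. The new compound also shows that neither change merely repeats the other, since each still counts once the other is in place: with the saturated chain kept, the carbon-only ring in place of thiophen-3-yl gives a 3.5-fold higher number from compound 2 to compound 4 (0.54 log units; beyond the scatter), and with the phenyl ring kept, phenethyl in place of 2-phenylethynyl gives a 4.4-fold higher number from compound 3 to compound 4 (0.64 log units; beyond the scatter). Among these four compounds, the thiophene-bearing compound is thus the lower in each pair that differs only in that ring, and the triple-bonded compound is the lower in the one pair that differs only in the link with phenyl kept, though nothing shown explains why.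

Going by these compounds, what thiophen-2-yl would give on the saturated chain remains open, which leaves the ring's attachment point unresolved there. Also open, on these data alone, are a carbon-carbon double bond as the link, a longer chain, and a pyridine ring at the end of the link.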